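The source may hold more compounds than are shown below. What is called first, only, known or untested is meant among the compounds shown, and "the series" means these compounds.

Compound 3 `O=C1CNC(=O)N1C[C@H]1CN(c2ccc(-n3cc(-c4ccccn4)cn3)c(F)c2)C(=O)O1` stands highest in a physicochemical assay for solubility, read by HPLC, with a stated time of 24 h (a lower number here means a less soluble compound, a higher number a more soluble compound), of the three compounds that share its core: in this assay compound 3 gives 1630000 nM, while compound 2 `CCN1CCN(C[C@H]2CN(c3ccc(-n4cc(-c5ccccn5)cn4)c(F)c3)C(=O)O2)CC1` gives 706000 nM and compound 1 `O=C1O[C@@H](CO)CN1c1ccc(-n2cc(-c3ccccn3)cn2)c(F)c1` gives 56400 nM. The step of a 2.3-fold higher number from compound 2 to compound 3 (0.36 log units; beyond the scatter) is modest, and the steps of a 13-fold higher number from compound 1 to compound 2 (1.10 log units; beyond the scatter) and a 29-fold higher number from compound 1 to compound 3 (1.46 log units; beyond the scatter) are large.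

Compound 4 `O=C1O[C@@H](Cn2ccnc2)CN1c1ccc(-n2cc(-c3ccccn3)cn2)c(F)c1` differs from compound 3 in one place: 1H-imidazol-1-yl in place of 2,5-dioxoimidazolidin-1-yl on a saturated chain carbon bound to a saturated ring carbon. Within the data shown here, no measured step exchanges one ring-bearing group for another of this kind, so the nearest guide is the modest step of a 2.3-fold higher number from compound 2 to compound 3 (0.36 log units; beyond the scatter), which sets 4-ethylpiperazin-1-yl only a short way from 2,5-dioxoimidazolidin-1-yl. An aromatic group with no hydrogen-bond donor is therefore expected to fall between compound 1 and compound 3 in this assay, nearer compound 2, giving an expected step of a 2.7-fold lower number from compound 3 to compound 4 (0.43 log units; beyond the scatter). For compound 4 the estimate in this assay is 600000 nM, expected to lie between 200000 nM and 1800000 nM.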

Compound 4, solubility: 12300 nM
Compound 4: the middle estimate sits 49-fold (1.69 log units) above what was measured, outside the stated range (below it).
By their numbers in this assay, from the lowest: compound 4; then compound 1; then compound 2; then compound 3.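

In this assay, a change on the saturated chain carbon bound to a saturated ring carbon can lower the number as well as raise it: both earlier replacements of hydroxy raised it, whereas 1H-imidazol-1-yl gives a 4.6-fold lower number from compound 1 to compound 4 (0.66 log units; beyond the scatter) and leaves compound 4 lowest of the four. The modest step between the two earlier ring-bearing groups did not show how wide the range at this place is, which now appears in a 130-fold lower number from compound 3 to compound 4 (2.12 log units; beyond the scatter) and in a 57-fold lower number from compound 2 to compound 4 (1.76 log units; beyond the scatter). Nothing measured here accounts for these falls.

On these data alone, it remains open whether a different five-membered aromatic ring, such as 1H-1,2,3-triazol-1-yl, would give a number near that of compound 4 or near that of compound 3. As far as these compounds go, how a carboxylic acid or a primary amine at this place would compare is also open.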